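Swapping Trifluoromethyl for Ethoxycarbonyl in Phenylethyl Ureas

The source may report more compounds than this note shows. Statements on the series, on what has been measured and on what is new or still open speak of the compounds shown alone.

Three ureas have been measured in an ADME assay on the whole organism with Oryza sativa as the target, tested at 10 uM; on this read-out lower numbers stand for a stronger effect and higher numbers for a weaker effect at the one concentration tested. Compound 1 `C[C@H](NC(=O)Nc1cccc(C(F)(F)F)c1)c1ccccc1` gives 92%. Compound 2 `C[C@@H](NC(=O)Nc1ccc(C(F)(F)F)cc1)c1ccccc1` is built from the same atoms joined differently, and in this assay compound 2 gives 82%; the difference between the two cores is not broken down here. Compound 3 `CCOC(=O)c1cccc(NC(=O)N[C@@H](C)c2ccccc2)c1` gives 96%. Compound 3 arises from compound 1 by one change, (ethoxycarbonyl in place of trifluoromethyl on an aromatic carbon), and that step is a number 4 percentage points higher from compound 1 to compound 3 (within the scatter). Compound 4 `CCOC(=O)c1ccc(NC(=O)N[C@H](C)c2ccccc2)cc1` is not yet measured; it arises from compound 2 by the same kind of change, (ethoxycarbonyl in place of trifluoromethyl on an aromatic carbon), although here the place is para to a large group rather than meta to a large group. Because a number 4 percentage points higher from compound 1 to compound 3 (within the scatter), the expected step is a number 4 percentage points higher from compound 2 to compound 4 (within the scatter). Compound 4 is thus estimated at 86%, with a likely range from 74% to 97%.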

Compound 4, a percentage reported as activity, at one concentration (the size of the read-out at that concentration, not a potency): 92%
The estimate for compound 4 lay 6 percentage points below the measured number, within the range that was stated.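

The new step, ethoxycarbonyl in place of trifluoromethyl on an aromatic carbon, is a number 10 percentage points higher from compound 2 to compound 4 (within the scatter) in this assay. Set beside the earlier step, it shows that the change behaves alike on these two cores, with no difference that can be told from scatter: the same change on two cores in this assay, a number 4 percentage points higher (within the scatter) from compound 1 to compound 3 and a number 10 percentage points higher (within the scatter) from compound 2 to compound 4, 6 percentage points apart, within the scatter of two such steps This does not show that the two steps are truly equal, and two pairs of compounds make no rule for other cores in the series.

All four compounds carry either trifluoromethyl or ethoxycarbonyl on that ring. From the compounds shown here alone, whether a carboxylic acid, a nitrile or an amine in the same place would give a similar number remains open.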